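Swapping the Triazole Attachment in Compound 3

The source may hold more compounds than are shown below. What is called first, only, known or untested is meant among the compounds shown, and "the series" means these compounds.

For the measured compounds named here, compound 3 `O=C(NCCCCCCCn1cc(-c2cccnc2)nn1)c1ccccc1-n1ccnn1` is the one compound of the three that gives a number in an assay for inhibition of Nicotinamide phosphoribosyltransferase (Mus musculus), read by fluorescence, with a stated time of 1 h, in the presence of a further agent that is not named here; a lower number here means a stronger inhibitor, a higher number a weaker inhibitor: compound 3 gives 3.4 nM. The two others share its core but carry a carboxyphenyl group instead of the 1H-1,2,3-triazol-1-yl group. Compound 1 `O=C(O)c1cccc(-c2ccccc2C(=O)NCCCCCCCn2cc(-c3cccnc3)nn2)c1` reaches only a limit of the assay, > 500 nM. Compound 2 `O=C(O)c1ccc(-c2ccccc2C(=O)NCCCCCCCn2cc(-c3cccnc3)nn2)cc1` likewise stops at a limit, > 500 nM. The steps of an at least 140-fold lower number from compound 1 to compound 3 (2.16 log units; beyond the scatter) and an at least 140-fold lower number from compound 2 to compound 3 (2.16 log units; beyond the scatter) therefore show only that the 1H-1,2,3-triazol-1-yl group gives a far stronger inhibitor than either carboxyphenyl, and the limit of > 500 nM in this assay, at which 2 of the 3 values shown sit, leaves the step that the two limits leave unreadable from compound 1 to compound 2 unreadable.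

Compound 4 `O=C(NCCCCCCCn1cc(-c2cccnc2)nn1)c1ccccc1-c1c[nH]nn1` keeps a triazole but joins it differently: 1H-1,2,3-triazol-4-yl in place of 1H-1,2,3-triazol-1-yl on an aromatic carbon. Going by the values given here, no measured step covers this kind of change; the measured steps say only that a small triazole here does far better than either carboxyphenyl. For compound 4 a modest step toward a higher number is expected: a 2.9-fold higher number from compound 3 to compound 4 (0.47 log units; beyond the scatter). Compound 4 is thus estimated at 10 nM, with a range from 2 nM to 60 nM.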

Compound 4, half-maximal inhibitory concentration: 42.5 nM
The estimate for compound 4 lay 4.3-fold (0.63 log units) below the measured number; the measured number falls inside the stated range.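

For the compounds shown here, compound 4 shows something the earlier compounds could not: at this position, how the triazole is attached matters as well as its presence, since the same atoms, joined differently, give a 13-fold higher number from compound 3 to compound 4 (1.10 log units; beyond the scatter). Even so, the 1H-1,2,3-triazol-4-yl group keeps a clear lead over both carboxyphenyl groups, with an at least 11-fold lower number from compound 2 to compound 4 (1.07 log units; beyond the scatter) and an at least 11-fold lower number from compound 1 to compound 4 (1.07 log units; beyond the scatter). These last two steps give only a minimum size, because each starts from a limit of the assay and not from a number: the limit of > 500 nM in this assay, at which 2 of the 4 values shown sit.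

The compounds shown do not separate the hydrogen-bond donor of the 1H-1,2,3-triazol-4-yl group, which the 1H-1,2,3-triazol-1-yl group lacks, from the change of attachment itself, and a methyl group on that triazole's nitrogen would bear on this. As far as these compounds go, how a tetrazole or an imidazole would fare at this position also stays open.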